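Smaller group on the ring nitrogen: compound 1 to compound 4

A few compounds are considered here, and "the series" means these few. Any claim that something is new, unique, unknown or untested is made for them only; others in the source may bear on it.

Measured in a functional assay on HepG2 cells (Homo sapiens) for antiproliferative activity, read by MTT assay, with a stated time of 72 h; a lower number here means a stronger inhibitor, a higher number a weaker inhibitor:
Compound 1 `COc1ccc(N2C(=O)COc3ccc(-c4cnc(OC)c(NS(=O)(=O)c5ccc(F)cc5)c4)cc32)cc1` gives 13100 nM.
Compound 2 `O=C1COc2ccc(-c3cnc4ccccc4c3)cc2N1c1ccc(Cl)cc1` gives 32700 nM.
Compound 3 `CC(C)N1C(=O)COc2ccc(-c3cccc(NS(=O)(=O)c4ccc(F)cc4)c3)cc21` gives only a limit of the assay, > 40000 nM.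

Among the two numbers, compound 1 has the lower one; compound 2 sits beyond the scatter from it, and compound 3 stands at the limit of > 40000 nM in this assay, at which 1 of the 3 values shown sits. Compound 4 `COc1ncc(-c2ccc3c(c2)N(C2CC2)C(=O)CO3)cc1NS(=O)(=O)c1ccc(F)cc1` differs from compound 1 in one place: cyclopropyl in place of 4-methoxyphenyl on an amide-type nitrogen in a ring. Among the compounds with values here, no measured pair shows this exact change, so its size can only be expected. The step from compound 1 to compound 4 is expected to weaken inhibition moderately, a 2.0-fold higher number from compound 1 to compound 4 (0.30 log units; within the scatter), beyond the scatter but well short of the limit. Compound 4 is therefore estimated at 26000 nM, expected between 9000 nM and 80000 nM in this assay.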

Compound 4, half-maximal inhibitory concentration: 14400 nM
For compound 4 the middle estimate is 1.8-fold (0.26 log units) above the measured one, within the range that was stated.
By their numbers in this assay, from the lowest: compounds 1 and 4 (each within the scatter of the next); then compound 2. At a limit, above all of these: compound 3.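

In this assay, putting cyclopropyl in place of 4-methoxyphenyl on the amide-type nitrogen gives a 1.1-fold higher number from compound 1 to compound 4 (0.04 log units; within the scatter) and so this position does not need a six-membered aromatic ring to keep activity at this level. The swap also removes a hydrogen-bond acceptor, yet the two numbers cannot be told apart. Nothing measured here explains why the swap makes so little difference.

Still open, going by these compounds, is whether a plain methyl, or a longer chain ending in an amine, would fit on this nitrogen equally well. Also open is whether the same swap would give a similar result on the other compounds shown.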